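The source may report more compounds than this note shows. Statements on the series, on what has been measured and on what is new or still open speak of the compounds shown alone.

Measured compounds:
Compound 1, `O=C1O[C@H]([C@@H](O)Cn2cc(CNS(=O)(=O)c3ccc(Cl)cc3)nn2)C(OCc2ccccc2)=C1OCc1ccccc1`, gives 38900 nM in a functional assay on CFPAC-1 cells (Homo sapiens) for antiproliferative activity, read by MTT assay, with a stated time of 72 h; a higher number here means a weaker inhibitor, a lower number a stronger inhibitor.
Compound 2, `Cc1ccc(-c2cn(C[C@H](O)[C@H]3OC(=O)C(OCc4ccccc4)=C3OCc3ccccc3)nn2)cc1`, is reported only as a limit of the assay in this assay: > 100000 nM.

Compound 2 thus stands at the limit of > 100000 nM in this assay, at which 1 of the 2 values shown sits, so no exact number is known for it; it is only known to be a weaker inhibitor than compound 1. Compound 3, `O=C1O[C@H]([C@@H](O)Cn2cc(CCO)nn2)C(OCc2ccccc2)=C1OCc1ccccc1`, differs from compound 2 in one place: 2-hydroxyethyl in place of 4-methylphenyl on an aromatic carbon. Among the measured compounds shown here, one measured step bears on this change: an at least 2.5-fold higher number from compound 1 to compound 2 (0.41 log units; beyond the scatter), where an aromatic ring entered in place of a chain-linked group and the number rose. Compound 3 takes the aromatic ring away again and brings in a short chain carrying a hydroxyl, so a somewhat lower number is expected, back toward the region of compound 1. The expected step, an at least 1.6-fold lower number from compound 2 to compound 3 (0.22 log units; that floor lies within the scatter), can be sized only loosely, as the starting point is a limit. Compound 3 is estimated at 60000 nM, within 20000 nM to 200000 nM.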

Compound 3, half-maximal inhibitory concentration: > 100000 nM
Compound 3: a limit, no number; the forecaster's own chance of this, stated with the estimate: 35%; middle value at least 1.6-fold (0.22 log units) from the limit.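

In this assay compound 3 gives > 100000 nM, which is a limit of the assay and not a number. So the aromatic ring of compound 2 is not the only group at this position that leaves the value out of reach: 2-hydroxyethyl does too, and exchanging the ((4-chlorophenyl)sulfonyl)amino group for a hydroxyl on the chain gives an at least 2.5-fold higher number from compound 1 to compound 3 (0.41 log units; beyond the scatter). Compound 1 remains the only one of the three with a readable value, and the step between the other two cannot be read, which sets a plain bound on any comparison here: the limit of > 100000 nM in this assay, at which 2 of the 3 values shown sit.

Going by these compounds, whether an amine, a carboxylic acid or a longer chain on this aromatic carbon would give a readable value stays open. On these data alone, it also stays open which part of the group in compound 1, the sulfonyl or the 4-chlorophenyl ring, matters for its value.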